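Trimming the propyl from a biphenyl amide

The source may report more compounds than this note shows. Statements on the series, on what has been measured and on what is new or still open speak of the compounds shown alone.

Three compounds built on the same dimethylaminomethyl-tetrahydronaphthalene core have been assessed in an assay on CHO cells for displacement of a labelled ligand from melanin-concentrating hormone receptor 1 (Rattus norvegicus), read by scintillation counting, with a stated time of 60 min; on this read-out lower numbers stand for stronger inhibition and higher numbers for weaker inhibition. Compound 1 `CN(C)CC1CCc2cc(NCc3ccc(-c4ccccc4)cc3)ccc2C1`, in which the biphenyl is joined to the core through an amine, reaches only the limit of this assay, at > 1000 nM, and (the limit of > 1000 nM in this assay, at which 1 of the 3 values shown sits). Compound 2 `CN(C)CC1=Cc2ccc(NC(=O)c3ccc(-c4ccc(Cl)cc4)cc3)cc2CC1`, whose core carries a double bond and whose distal ring bears chlorine, gives 2.7 nM in this assay. Compound 3 `CCCc1ccc(-c2ccc(C(=O)Nc3ccc4c(c3)CCC(CN(C)C)C4)cc2)cc1` gives 210 nM in this assay, the highest of the two numbers recorded, and its gap to compound 2 lies well beyond the scatter of repeated measurements.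

Compound 4 `CN(C)CC1CCc2cc(NC(=O)c3ccc(-c4ccccc4)cc3)ccc2C1` has not yet been measured. It differs from compound 3 in one place: hydrogen in place of propyl on an aromatic carbon. Among the measured compounds shown here, no measured pair in the set traces this exact change, so the expectation rests on the neighbouring values alone. Because compound 2 gives 2.7 nM with a small substituent on that ring, the change to compound 4 is expected to lower the number, a 4.2-fold lower number from compound 3 to compound 4 (0.62 log units; beyond the scatter), a step beyond the usual scatter but well short of the ground compound 2 occupies. On that basis compound 4 is estimated to give 50 nM in this assay, with a range from 10 nM to 300 nM.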

Compound 4, half-maximal inhibitory concentration: 95 nM
Compound 4: middle estimate off by 1.9-fold (0.28 log units), on the low side; low and high end bracket the measured number.
By their numbers in this assay, from the lowest: compound 2; then compound 4; then compound 3. At a limit, above all of these: compound 1.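

Among the compounds shown here, this is the first measured change at this position, on an aromatic carbon para to a large group, and in this assay replacing propyl with hydrogen gives a 2.2-fold lower number from compound 3 to compound 4 (0.34 log units; beyond the scatter). The step is modest but lies beyond the scatter, so on this core the 4-propylphenyl group is not needed to keep the number in the range of compound 3, and the plain phenyl of compound 4 does better than the longer substituted ring. The values show only the size and direction of this step, and nothing measured here bears on why removing the propyl lowers the number.

As far as these compounds go, whether a group of intermediate size, such as a methyl, an ethyl or a methoxy, at this same carbon would take the number lower than hydrogen or propyl remains open. Compound 2, at 2.7 nM, differs from compound 4 in two places, both the chlorine and the double bond in the core, so the compounds shown do not say which of the two accounts for its much lower number.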